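The source may report more compounds than this note shows. Statements on the series, on what has been measured and on what is new or still open speak of the compounds shown alone.

The series shares the core of compound 1 `COc1cccc(/C=C/C(=O)c2c(OC)cc(OC)cc2OC)c1`, which in a functional assay on Caco-2 cells (Homo sapiens), read by fluorescence and BrdU incorporation, with a stated time of 48 h, tested at 10 uM (on this read-out lower numbers stand for a stronger effect and higher numbers for a weaker effect at the one concentration tested), gives 31%. Compound 2 `COc1cc(OC)c(C(=O)/C=C/c2ccccc2)c(OC)c1` gives 38%, and compound 3 `COc1cc(OC)c(C(=O)/C=C/c2ccc(Cl)cc2)c(OC)c1` gives 39%. Compound 3 stands within the scatter of both other numbers: a number 8 percentage points higher from compound 1 to compound 3 (within the scatter), and a number 1 percentage points higher from compound 2 to compound 3 (within the scatter); the step of a number 7 percentage points higher from compound 1 to compound 2 (within the scatter) is of the same kind, so nothing among the three compounds is separated beyond the scatter. Compound 4 `COc1cc(OC)c(C(=O)/C=C/c2ccc(F)cc2)c(OC)c1` is not yet measured. Its difference from compound 3 is fluoro in place of chloro on an aromatic carbon. The step that bears most directly on this change is the one in which chloro came in on an aromatic carbon, a number 1 percentage points higher from compound 2 to compound 3 (within the scatter), which lay within the scatter; the step of a number 8 percentage points higher from compound 1 to compound 3 (within the scatter), which brought the 4-chlorophenyl in, was also within the scatter. Within the data shown here, no measured step moved beyond the scatter, so in this assay no step beyond the scatter is expected from compound 3 to compound 4 either, a number 1 percentage points lower from compound 3 to compound 4 (within the scatter). Compound 4 is therefore estimated at 38%, with a range from 27% to 49%.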

Compound 4, a percentage reported as activity, at one concentration (the size of the read-out at that concentration, not a potency): 39%
Estimate against measurement, compound 4: 1 percentage points below; measured number inside the range.
By their numbers in this assay, from the lowest: compounds 1, 2, 3 and 4 (each within the scatter of the next).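

In this assay, exchanging the halogen on the aromatic carbon para to a large group leaves the read-out within the scatter, with fluoro in place of chloro giving (no change at the digits printed from compound 3 to compound 4 (within the scatter)). Fluoro in place of hydrogen at this place gives (a number 1 percentage points higher from compound 2 to compound 4 (within the scatter)), and the wider change from 3-methoxyphenyl to 4-fluorophenyl gives (a number 8 percentage points higher from compound 1 to compound 4 (within the scatter)), so fluoro, like chloro, adds no step beyond the scatter. No supporting data bear on why these compounds read alike.

As far as these compounds go, whether an amine or a carboxylic acid at this same place would move the number beyond the scatter remains open. The compounds shown also leave open whether their closeness at the one concentration tested would hold at other concentrations.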